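A few compounds are considered here, and "the series" means these few. Any claim that something is new, unique, unknown or untested is made for them only; others in the source may bear on it.

Among the measured compounds shown here, in an ADME assay on microsomes from liver (Rattus norvegicus, strain Sprague-Dawley) for metabolic stability, read by LC-MS, using NADPH, with a stated time of 30 min, tested at 3 uM (on this read-out higher numbers stand for a more stable compound and lower numbers for a less stable compound), compound 2 `COc1ncc(-c2ccc(-c3cnc4c(c3)CN(C)C4=O)s2)cc1NS(=O)(=O)c1ccc(F)cc1F` gives 100%, the highest of the two numbers measured so far, while the nearest, compound 1 `CN1Cc2cc(-c3ccc(-c4cncc(NS(=O)(=O)c5cccc(C(F)(F)F)c5)c4)s3)cnc2C1=O`, gives 84%, a gap that lies beyond the scatter. Compound 3 `CN1Cc2cc(-c3ccc(-c4cncc(NS(=O)(=O)c5ccc(F)cc5F)c4)s3)cnc2C1=O` differs from compound 2 in one place: hydrogen in place of methoxy on an aromatic carbon. For the measured compounds named here, no measured pair shows this change by itself, so its effect cannot be read from the data. A modest fall is expected, because compound 1 gives only 84%. Compound 3 is therefore estimated at 88%, between 70% and 100%. The expected step is a number 12 percentage points lower from compound 2 to compound 3 (beyond the scatter).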

Compound 3, percent of the compound remaining: 100%
The estimate for compound 3 lay 12 percentage points below the measured number, and the stated range covers the measured number.
By their numbers in this assay, from the lowest: compound 1; then compounds 2 and 3 (each within the scatter of the next).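

In this assay hydrogen in place of methoxy on this aromatic carbon gives no change at the digits printed from compound 2 to compound 3 (within the scatter) and so, on this read-out, the position carries either group without a visible difference. Among the compounds shown here, with that core held constant, 2,4-difluorophenyl in place of 3-(trifluoromethyl)phenyl on the sulfonyl sulfur gives a number 16 percentage points higher from compound 1 to compound 3 (beyond the scatter) and this is the first comparison of the sulfonyl group in one place. Nothing shown gives a reason for either step. The compounds shown leave open how an amine or an ethoxy group would fare on this carbon, and how a plain phenyl would fare on the sulfonyl sulfur.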